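The source may report more compounds than this note shows. Statements on the series, on what has been measured and on what is new or still open speak of the compounds shown alone.

Compound 1 `Nc1cc(N)c2nc(-c3ccccc3)c(Oc3ccc(Cl)c(Cl)c3)nc2c1` gives 47900 nM in a functional assay on ACHN cells (Homo sapiens) for inhibition, read by sulforhodamine B assay, with a stated time of 48 h; on this read-out higher numbers stand for weaker inhibition of growth and lower numbers for stronger inhibition of growth.
Compound 2 `COc1ccc(CNc2nc3cc(N)cc(N)c3nc2-c2ccccc2)cc1OC` gives 33100 nM in this assay.
Compound 3 `COc1cc(CNc2nc3cc(N)cc(N)c3nc2-c2ccccc2)cc(OC)c1OC` gives 11200 nM in this assay.

Among these three numbers compound 2 stands second highest; its value and that of compound 1 lie within the usual scatter of each other, while compound 3 sits beyond it. Going by the values given here, the one step between measured compounds that differ in a single place runs from compound 2 to compound 3 with a 3.0-fold lower number from compound 2 to compound 3 (0.47 log units; beyond the scatter), the change being methoxy in place of hydrogen on an aromatic carbon. Compound 4 `Nc1cc(N)c2nc(-c3ccccc3)c(NCc3ccc(F)cc3)nc2c1` has not been measured; it differs from compound 2 by 4-fluorophenyl in place of 3,4-dimethoxyphenyl on a saturated chain carbon bound to a nitrogen on an aromatic ring. Among the compounds with values here, that single measured step bears on it only indirectly: adding methoxy lowered the number, and the change to compound 4 takes away the methoxy groups of compound 2 while bringing in fluorine, so a modest step toward a higher number is expected, although no measured step shows this kind of change. For compound 4 the expected number is 55000 nM, estimated to lie between 22000 nM and 130000 nM, which would mean an expected 1.7-fold higher number from compound 2 to compound 4 (0.22 log units; within the scatter) in this assay.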

Compound 4, concentration for total growth inhibition: 3090 nM
The estimate for compound 4 lay 18-fold (1.25 log units) above the measured number; the measured number lies below the stated range.
By their numbers in this assay, from the lowest: compound 4; then compound 3; then compounds 2 and 1 (each within the scatter of the next).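

In this assay the aryl group on a saturated chain carbon bound to a nitrogen on an aromatic ring turns out to matter far more than the methoxy step suggested: that step gave a 3.0-fold lower number from compound 2 to compound 3 (0.47 log units; beyond the scatter) and yet 4-fluorophenyl in place of 3,4-dimethoxyphenyl gives an 11-fold lower number from compound 2 to compound 4 (1.03 log units; beyond the scatter) with no methoxy left at all, so adding methoxy is not the only route to a lower number here. The exchange of 3,4-dichlorophenoxy for (4-fluorobenzyl)amino on an aromatic carbon of the shared core gives a 16-fold lower number from compound 1 to compound 4 (1.19 log units; beyond the scatter) as a second large step, which shows that this read-out responds strongly to the group at that carbon. No evidence at hand accounts for either step.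

From the compounds shown here alone, whether the drop follows from the fluorine or from the loss of the methoxy groups remains open, and a plain unsubstituted phenyl on the same chain carbon would separate the two. Going by these compounds, how a longer chain or a carboxylic acid on this ring would read also remains unknown.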